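Methyl on the Benzothiazole Ring of a Weak Porcupine Inhibitor

This account rests on a few compounds, and the source may have more. Where it says the series, first, only, none or still open, it means among the compounds named here.

Compound 1 `COc1ccc(-n2nc(C(=O)NCC(=O)Nc3nc4ccccc4s3)c3ccccc3c2=O)cc1` is the weaker of the two measured compounds in an assay on L cells for inhibition of Protein-serine O-palmitoleoyltransferase porcupine (Mus musculus), read by reporter gene assay, with a stated time of 24 h; on this read-out lower numbers stand for an effect already at smaller amounts and higher numbers for an effect only at larger amounts of compound: compound 1 gives 25000 nM, while compound 2 `O=C(CNC(=O)c1nn(-c2ccccc2)c(=O)c2ccccc12)Nc1nc2ccccc2s1` gives 2600 nM. Among the measured compounds shown here, the only measured step, a 9.6-fold lower number from compound 1 to compound 2 (0.98 log units; beyond the scatter), concerns the methoxy group on the other aromatic ring and therefore says nothing direct about the part changed here. Compound 3 `COc1ccc(-n2nc(C(=O)NCC(=O)Nc3nc4ccc(C)cc4s3)c3ccccc3c2=O)cc1` differs from compound 1 by methyl in place of hydrogen on an aromatic carbon, so that 1,3-benzothiazol-2-yl becomes 6-methyl-1,3-benzothiazol-2-yl. For the measured compounds named here, no measured step touches this ring, so no direction can be taken from the data, and a change within the scatter is the plainest expectation. Compound 3 is therefore estimated to give 20000 nM in this assay, with a range from 7000 nM to 60000 nM, a step of a 1.3-fold lower number from compound 1 to compound 3 (0.10 log units; within the scatter) that is expected to stay within the scatter.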

Compound 3, half-maximal effective concentration: 25 nM
Estimate against measurement, compound 3: 800-fold (2.90 log units) above, outside the stated range (below it).
By their numbers in this assay, from the lowest: compound 3; then compound 2; then compound 1.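

Among the compounds shown here, changing 1,3-benzothiazol-2-yl to 6-methyl-1,3-benzothiazol-2-yl gives a 1000-fold lower number from compound 1 to compound 3 (3.00 log units; beyond the scatter) in this assay, so this place on the ring, which the earlier compounds left untouched, has a very strong bearing on the read-out. This step is also much larger than the only earlier one, a 9.6-fold lower number from compound 1 to compound 2 (0.98 log units; beyond the scatter), which replaced methoxy with hydrogen on the other aromatic ring. Nothing available here explains why so small an addition has so large an effect.

Going by these compounds, it remains open whether methyl is special at this place, or whether a longer chain such as ethyl, a chlorine atom or an amine would serve equally well. On these data alone, it is also open whether the same methyl would bring a similar step to compound 2, which carries hydrogen in place of methoxy.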